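The compounds below may be only part of what the source reports. "The series", "measured", "known", "first", "only" and "open" are said of these compounds alone.

Measured compounds:
Compound 1, `Cc1ccnc(/C(N)=N/NC(=S)N2CCSCC2)c1`, in a functional assay on A-431 cells (Homo sapiens) for cytotoxicity, read by MTT assay, with a stated time of 72 h, tested at 10 uM (on this read-out higher numbers stand for more inhibition of growth at the one concentration tested and lower numbers for less inhibition of growth), gives 60%.
Compound 2, `N/C(=N\NC(=S)N1CCCCC1)c1ccccn1`, in this assay gives 68.1%.

Among the two numbers, compound 2 stands highest, but its nearest neighbour, compound 1, lies close enough that the gap between them is within the usual scatter; the two compounds cannot be ranked against each other on this read-out. Among the compounds with values here, no step between the two measured compounds is given, as they differ in more than one place, so their values are simply what each shows on its own.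

Compound 3, `Cc1ccnc(/C(N)=N/NC(=S)N2CCCCC2)c1`, is the one still to be measured. It differs from compound 2 by methyl in place of hydrogen on an aromatic carbon. No measured step of this kind exists among the compounds shown, so there is nothing to set a size from; the expectation is that the change moves this assay by no more than the scatter, in no settled direction. Compound 3 is therefore expected to give about 64%, with a range from 45% to 80%. This estimate means a step of a number 4.1 percentage points lower from compound 2 to compound 3 (within the scatter) that is expected to stay within the scatter.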

Compound 3, percent growth inhibition at one concentration: 39.7%
Beside the measured number, compound 3's estimate is 24.3 percentage points above it; the measured number lies below the stated range.
By their numbers in this assay, from the lowest: compound 3; then compounds 1 and 2 (each within the scatter of the next).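

In this assay, methyl in place of hydrogen on the aromatic carbon opposite the ring nitrogen proves not to be a silent change, as it brings a number 28.4 percentage points lower from compound 2 to compound 3 (beyond the scatter) and thereby gives this position its first measured step. With that methyl present, the group on the thiocarbonyl carbon also counts, since piperidin-1-yl in place of thiomorpholin-4-yl brings a number 20.3 percentage points lower from compound 1 to compound 3 (beyond the scatter) and so shows a step that the earlier pair, differing in more than one place, could not isolate. Nothing in the data on hand accounts for either step.

The compounds shown leave open whether the methyl step has the same size and direction when thiomorpholin-4-yl sits on the thiocarbonyl carbon, and likewise whether the step between those two groups holds without the methyl. They also leave open whether the loss belongs to methyl alone or would recur with another group on that aromatic carbon, such as chlorine, methoxy or ethyl.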